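The compounds below may be only part of what the source reports. "The series", "measured", "known", "first", "only" and "open" are said of these compounds alone.

Among the measured compounds shown here, compound 3 `CC(C)COc1cccc(O)c1C(=O)/C=C/c1ccc(O)cc1` stands lowest of the two numbers so far obtained in an assay on THP-1 cells for inhibition of nuclear factor NF-kappa-B complex (Homo sapiens), with stated times of 2 h and 16 h; on this read-out higher numbers stand for weaker inhibition and lower numbers for stronger inhibition: compound 3 gives 8000 nM. Nearest is compound 2 `CCC(CC)COc1cccc(O)c1C(=O)/C=C/c1ccc(O)cc1`, which in this assay gives 12000 nM; the step of a 1.5-fold lower number from compound 2 to compound 3 (0.18 log units; within the scatter) lies within the scatter, so no order between the two is claimed. Compound 1 `O=C(/C=C/c1ccc(O)cc1)c1c(O)cccc1OCCC1CCCCC1` returns only a limit of the assay in this assay, namely > 30000 nM (the limit of > 30000 nM in this assay, at which 1 of the 3 values shown sits). Compound 4 `O=C(/C=C/c1ccc(O)cc1)c1c(O)cccc1OCCC1CCCC1` is not yet measured; it differs from compound 3 as follows: cyclopentylmethyl in place of isopropyl on a saturated chain carbon bound to an oxygen on an aromatic ring. The measured steps that bear on this are an at least 3.7-fold lower number from compound 1 to compound 3 (0.57 log units; beyond the scatter) and an at least 2.5-fold lower number from compound 1 to compound 2 (0.39 log units; beyond the scatter), both running from cyclohexylmethyl to an open-chain group with lower numbers. The change to compound 4 runs the other way, from isopropyl to a group carrying a five-membered ring, though cyclopentylmethyl is not cyclohexylmethyl. A rise in the number is therefore expected, a 2.5-fold higher number from compound 3 to compound 4 (0.40 log units; beyond the scatter), with a real chance that only a limit is returned. Compound 4 is estimated at 20000 nM, between 8000 nM and 50000 nM.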

Compound 4, half-maximal inhibitory concentration: 18000 nM
Beside the measured number, compound 4's estimate is 1.1-fold (0.05 log units) above it, and the stated range covers the measured number.
By their numbers in this assay, from the lowest: compounds 3, 2 and 4 (each within the scatter of the next, the first and the last beyond it). At a limit, above all of these: compound 1.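

In this assay, cyclopentylmethyl in place of isopropyl on a saturated chain carbon bound to an oxygen on an aromatic ring gives a 2.3-fold higher number from compound 3 to compound 4 (0.35 log units; beyond the scatter), so a group carrying a five-membered ring also stands beyond the scatter from isopropyl, while a 1.5-fold higher number from compound 2 to compound 4 (0.18 log units; within the scatter) sets no order between cyclopentylmethyl and pentan-3-yl, and a ring alone therefore does not separate compound 4 from the open-chain compound 2. The change of cyclopentyl in place of cyclohexyl, an at least 1.6-fold lower number from compound 1 to compound 4 (0.22 log units; that floor lies within the scatter), cannot be read as a difference between the two rings. Compound 1 stands at a limit, not a number: the limit of > 30000 nM in this assay, at which 1 of the 4 values shown sits.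

Still open, as far as these compounds go, is whether a shorter group such as ethyl, or a longer straight chain such as hexyl, would fall below compound 3. Also open, from the compounds shown here alone, is how an amine or a carboxylic acid on this chain would read.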